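A few compounds are considered here, and "the series" means these few. Any claim that something is new, unique, unknown or untested is made for them only; others in the source may bear on it.

Compound 2 `COc1cccc(CNCCCNc2ccnc3cc(Cc4ccccc4)ccc23)c1O` gives 9.47 in a physicochemical assay for acid dissociation. Among the compounds with values here, it stands level with compound 1 `COc1cccc(CNCCCNc2ccnc3cc(C4CCCCC4)ccc23)c1O`, which in this assay gives 9.47; the only measured step here, no change at the digits printed from compound 1 to compound 2 (within the scatter), exchanged one group for another on an aromatic carbon and left the read-out unchanged within the scatter. Compound 3 `COc1cccc(CNCCCNc2ccnc3cc(-c4cccc5ccccc45)ccc23)c1O` has not yet been measured. It differs from compound 2 in one place: naphthalen-1-yl in place of benzyl on an aromatic carbon. Within the data shown here, the one measured step that bears on this change is the exchange on an aromatic carbon already described, and it amounted to no change at the digits printed from compound 1 to compound 2 (within the scatter), which is no shift at all beyond the scatter. With nothing in the measured compounds showing that an exchange of this kind moves this assay, the step expected from compound 2 to compound 3 is no change at the digits printed from compound 2 to compound 3 (within the scatter), that is, none beyond the scatter. Compound 3 is therefore estimated to give 9.47 in this assay, with a range from 9.15 to 9.8.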

Compound 3, acid dissociation constant: 9.47
Compound 3: the middle estimate sits on the measured number at the digits printed, and the stated range covers the measured number.
By their numbers in this assay, from the lowest: compounds 1, 2 and 3 (each within the scatter of the next).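

In this assay, putting naphthalen-1-yl in place of benzyl on this aromatic carbon gave no change at the digits printed from compound 2 to compound 3 (within the scatter), and putting it in place of cyclohexyl gave no change at the digits printed from compound 1 to compound 3 (within the scatter). The earlier pair showed only that benzyl and cyclohexyl read alike, whereas this result extends that to a group with two six-membered aromatic rings of carbon only and more heavy atoms than either, so across these three carbon-only groups with no net charge, the read-out at this position does not separate them. Nothing measured here offers an explanation for this lack of change.

From the compounds shown here alone, all three groups consist of carbon and hydrogen alone, so it remains open whether an amine or a carboxylic acid on this same aromatic carbon, which would bring in atoms other than carbon, would shift the number in this assay. The rest of the molecule is also identical in all three compounds, which leaves open what a longer chain elsewhere on the shared core would do, and which proton in the molecule this number reports.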